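The source may report more compounds than this note shows. Statements on the series, on what has been measured and on what is new or still open speak of the compounds shown alone.

Measured compounds:
- compound 1, `C/C=C/C(=O)N(Cc1ccc(OC)c(OC)c1)c1cc(OC)c(OC)c(OC)c1`, giving 20100 nM in a functional assay on MGC-803 cells (Homo sapiens) for inhibition, read by MTT assay, with a stated time of 48 h; on this read-out lower numbers stand for stronger inhibition and higher numbers for weaker inhibition
- compound 2, `C/C=C/C=C/C(=O)N(Cc1ccc(OC)c(O)c1)c1cc(OC)c(OC)c(OC)c1`, giving 140 nM in this assay
- compound 3, `COc1ccc(CNc2cc(OC)c(OC)c(OC)c2)cc1F`, giving 39700 nM in this assay

Among these three, compound 2 stands with the lowest number, and its two neighbours lie far away from it: compound 1 shows a much higher number and compound 3 a higher one still, both gaps well beyond the scatter of repeated measurements. Within the data shown here, compound 1 and compound 3 each differ from compound 2 in more than one place, so no single step between measured compounds is available to separate the contributions of the amide group and the substituents on the benzyl ring.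

The unmeasured compound 4, `COc1ccc(CN(C(=O)C2CC2)c2cc(OC)c(OC)c(OC)c2)cc1O`, keeps the benzyl ring and the core of compound 2 and alters only the acyl group: cyclopropyl in place of penta-1,3-dien-1-yl on a carbonyl carbon

Among the measured compounds shown here, with no measured step for this exchange, the expectation for compound 4 rests on the spread of the three values alone. Compound 4 is expected to give a number higher than compound 2 in this assay, by a step that lies beyond the scatter, estimated as a 14-fold higher number from compound 2 to compound 4 (1.15 log units; beyond the scatter), with wide uncertainty. The estimated value for compound 4 is 2000 nM, with a plausible range from 300 nM to 15000 nM.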

Compound 4, half-maximal inhibitory concentration: 59 nM
Estimate against measurement, compound 4: 34-fold (1.53 log units) above, and the stated range ends above it.
By their numbers in this assay, from the lowest: compound 4; then compound 2; then compounds 1 and 3 (each within the scatter of the next).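

In this assay, among these compounds, the exchange gives the first step that changes one place only, and a 2.4-fold lower number from compound 2 to compound 4 (0.38 log units; beyond the scatter) shows that the penta-1,3-dien-1-yl group on this carbonyl carbon can be replaced without losing inhibition; the number even falls modestly, by a step beyond the scatter. The entering cyclopropyl has 3 heavy atoms against 5 and a three-membered ring instead of 2 double bonds outside aromatic rings, which shows that, with this benzyl ring and core, neither the open chain nor those double bonds are required for a low number. Nothing available explains why the number falls with this exchange.

On these data alone, it remains open whether an acetyl group, a cyclobutyl group or a saturated pentyl chain on the same carbonyl carbon would keep a number as low as that of compound 4 59 nM or lose it. As far as these compounds go, the part played by the hydroxyl on the benzyl ring also stays open, as does the result of replacing it with an amine or a carboxylic acid.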